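The compounds below may be only part of what the source reports. "The series", "measured", "known", "first", "only" and "open" are said of these compounds alone.

Measured so far in an assay on FRT-Jurkat cells for inhibition of nuclear factor NF-kappa-B complex (Homo sapiens), read by flow cytometry, with a stated time of 24 h, tested at 10 uM; on this read-out lower numbers stand for less inhibition and higher numbers for more inhibition at the one concentration tested (going by the name of the read-out): compound 1 `Cc1ccccc1Nc1cccc2c1C(=O)N(C1CCC(=O)NC1=O)C2=O` gives 7%; compound 2 `CC(C)c1ccc(Nc2cccc3c2C(=O)N(C2CCC(=O)NC2=O)C3=O)cc1` gives 19%; compound 3 `CC(C)c1ccc(Nc2ccc3c(c2)C(=O)N(C2CCC(=O)NC2=O)C3=O)cc1` gives 11%.

Compound 2 and compound 3 are built from the same atoms joined differently; the difference between their two cores is not broken down here. On the core of compound 2, the change 2-methylphenyl in place of 4-isopropylphenyl on a nitrogen on an aromatic ring gave a number 12 percentage points lower from compound 2 to compound 1 (beyond the scatter). Compound 4 `Cc1ccccc1Nc1ccc2c(c1)C(=O)N(C1CCC(=O)NC1=O)C2=O`, not yet measured, carries the same change on the core of compound 3: 2-methylphenyl in place of 4-isopropylphenyl on a nitrogen on an aromatic ring. This change has been seen once in measured compounds, with the step just described. The step from compound 3 to compound 4 in this assay is expected to be a number 9 percentage points lower from compound 3 to compound 4 (within the scatter), a drop of similar size to the earlier one. For the measured compounds named here, that expectation rests on the single measured step of a number 12 percentage points lower from compound 2 to compound 1 (beyond the scatter) and on compound 3 already standing at 11%. Compound 4 is therefore estimated at 2%, expected to fall between -8% and 12%.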

Compound 4, a percentage reported as inhibition, at one concentration (the size of the read-out at that concentration, not a potency): 2%
Estimate against measurement, compound 4: no gap at the digits printed, and the stated range covers the measured number.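

In this assay, placing 2-methylphenyl for 4-isopropylphenyl on the core of compound 3 gave a number 9 percentage points lower from compound 3 to compound 4 (within the scatter). Set beside the earlier step, this shows that the change carried over between these two cores with no difference that can be told apart: the same change on two cores in this assay, a number 12 percentage points lower (beyond the scatter) from compound 2 to compound 1 and a number 9 percentage points lower (within the scatter) from compound 3 to compound 4, 3 percentage points apart, within the scatter of two such steps It rests on only two cores and one pair of groups, and since the new step lies within the scatter, it does not establish a real drop on the core of compound 3 or show how the change would behave on any other core.

The compounds shown leave open what other groups on this nitrogen would give, such as a cyclohexyl ring, a longer alkyl chain or a phenyl ring carrying a carboxylic acid. For the compounds shown here, each compound also has only a single reading at one concentration in this assay, so their potency remains open.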